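The source may hold more compounds than are shown below. What is called first, only, known or untested is meant among the compounds shown, and "the series" means these compounds.

Compound 1, `CC(=O)OCCCS(=O)(=O)c1ccc(S(N)(=O)=O)s1`: 8.05
Compound 2, `NS(=O)(=O)c1ccc(S(=O)(=O)CCCCO)s1`: 8.67
Compound 3, `CC(=O)OCCCCc1ccc(S(N)(=O)=O)cc1`: 10.5

These numbers come from a physicochemical assay for acid dissociation. Compound 1 and compound 2 share one core and differ by a single change, (hydroxymethyl in place of acetoxy on a saturated chain carbon, three bonds along the chain from a sulfonyl sulfur); this change gave the step of a number 0.62 log units higher from compound 1 to compound 2 (beyond the scatter). Compound 3 has a different core, and the difference between the core of compound 1 and the core of compound 3 is not broken down here; what the values show is that compound 3 sits highest of the three, with compound 2 nearest and compound 1 furthest.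

Compound 4, `NS(=O)(=O)c1ccc(CCCCCO)cc1`, has not yet been measured. It differs from compound 3 by hydroxymethyl in place of acetoxy on a saturated chain carbon, four bonds along the chain from an aromatic carbon. The change is the same kind as that from compound 1 to compound 2, but not the same: there the place was three bonds along the chain from a sulfonyl sulfur, here it is four bonds along the chain from an aromatic carbon. Within the data shown here, the only guide is the measured step of a number 0.62 log units higher from compound 1 to compound 2 (beyond the scatter). The expected step is therefore a number 0.40 log units higher from compound 3 to compound 4 (beyond the scatter), taken a little smaller than the measured step because the guide is a number 0.62 log units higher from compound 1 to compound 2 (beyond the scatter) and the place is not identical. Compound 4 is thus expected to give 10.9, most likely between 10.4 and 11.4.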

Compound 4, acid dissociation constant: 10.3
Compound 4: middle estimate off by 0.60 log units, on the high side; measured number below the stated range.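

In this assay, putting hydroxymethyl in place of acetoxy gave a number 0.62 log units higher from compound 1 to compound 2 (beyond the scatter), while the same kind of change on the other core gave a number 0.20 log units lower from compound 3 to compound 4 (within the scatter), so the step seen on the first core did not carry over to this second pair. This does not show that the core alone decides the outcome: the place differs too, three bonds along the chain from a sulfonyl sulfur in one pair and four bonds along the chain from an aromatic carbon in the other, and two pairs are too few to support a rule. Nothing available here explains why the two results differ.

Still open, going by these compounds, is how the change behaves when both cores carry it at the same place, which would separate the role of the core from that of the place. Also open, on these data alone, is what a carboxylic acid or an amine in place of hydroxymethyl at the end of the chain would give in this assay on either core.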